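The compounds below may be only part of what the source reports. "The series", "measured", "known", "first", "only" and "open" are said of these compounds alone.

Among the measured compounds shown here, the series so far holds two measured compounds, compound 1 `Cc1nc(C)c(C(=O)Oc2ccccc2/C=C/C(=O)O)nc1C` and compound 2 `COc1ccc(OC(=O)c2nc(C)c(C)nc2C)c(/C=C/C(=O)O)c1`, which differ by a methoxy in place of hydrogen on an aromatic carbon. In a functional assay on EA.hy 926 cells (Homo sapiens) for cytotoxicity, read by MTT assay, with stated times of 24 h and 12 h, tested at 100 uM (on this read-out lower numbers stand for a weaker effect and higher numbers for a stronger effect at the one concentration tested), compound 1 gives 80.1%, and in this assay compound 2 gives 79.2%. For the measured compounds named here, the one measured step is a number 0.9 percentage points lower from compound 1 to compound 2 (within the scatter). Compound 2 thus stands at one of two numbers, the other belonging to compound 1, with a gap between them that lies within the scatter, so no ranking of the two is possible.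

The next compound, compound 3 `CCOC(=O)/C=C/c1cc(OC)ccc1OC(=O)c1nc(C)c(C)nc1C`, derives from compound 2 by ethyl in place of hydrogen on an oxygen next to a carbonyl group. Going by the values given here, no measured step touches this place: the only step available, a number 0.9 percentage points lower from compound 1 to compound 2 (within the scatter), concerns a substituent on an aromatic carbon and is within the scatter, so it gives no direct guidance for a change on an oxygen next to a carbonyl group. Among the compounds with values here, with no comparable step to draw on, the working expectation in this assay is a step of a number 1.2 percentage points lower from compound 2 to compound 3 (within the scatter), that is, no shift beyond the scatter, with a range kept wide for this untested kind of change. Compound 3 is therefore expected to give about 78% in this assay, between 58% and 92%.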

Compound 3, a percentage reported as activity, at one concentration (the size of the read-out at that concentration, not a potency): 46.2%
Estimate against measurement, compound 3: 31.8 percentage points above, and the stated range ends above it.
By their numbers in this assay, from the lowest: compound 3; then compounds 2 and 1 (each within the scatter of the next).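

Working notes on the series: the methoxy change on the aromatic carbon stayed within the scatter, whereas the change at the oxygen next to a carbonyl group, carboxy to ethoxycarbonyl, is the first to move the read-out in this assay, the step being a number 33 percentage points lower from compound 2 to compound 3 (beyond the scatter). With lower numbers standing for a weaker effect at the one concentration tested, the ethyl ester compound 3 is clearly weaker here than the free acid compound 2, so this position responds to substitution in a way the aromatic carbon has not so far. Nothing at hand bears on why this change has so large an effect on the read-out.

The compounds shown leave open whether this step belongs to ethyl itself or to any replacement of the acid hydrogen, which a methyl ester, a longer chain such as butyl, or an amide in place of the ester would help to separate. They also leave open whether the same step appears without the methoxy group, since the core of compound 1 carries the free acid only.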